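The compounds below may be only part of what the source reports. "The series", "measured", "known", "first", "only" and "open" are said of these compounds alone.

Measured compounds in an assay on H4 cells for inhibition of Fatty-acid amide hydrolase 1 (Homo sapiens); a higher number here means a weaker inhibitor, a lower number a stronger inhibitor:
compound 1 `CCCCOc1ccc(NC(=O)Oc2ccccc2F)cc1` gives 340 nM
compound 2 `CCCCCCCOc1ccc(NC(=O)Oc2ccccc2F)cc1` gives 28 nM
compound 3 `CCCCCCCCOc1ccc(NC(=O)Oc2ccccc2F)cc1` gives 19 nM

Compound 3 carries the lowest number of the three, though its gap to compound 2 lies within the scatter (a 1.5-fold lower number from compound 2 to compound 3 (0.17 log units; within the scatter)); only compound 1 stands clearly apart from it (an 18-fold lower number from compound 1 to compound 3 (1.25 log units; beyond the scatter)).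

Compound 4 `CCCCCCCCCCCCOc1ccc(NC(=O)Oc2ccccc2F)cc1` differs from compound 3 by butyl in place of hydrogen on a saturated chain carbon, eight bonds along the chain from an oxygen on an aromatic ring. Lengthening of this chain has been followed twice already: the steps of a 12-fold lower number from compound 1 to compound 2 (1.08 log units; beyond the scatter) and an 18-fold lower number from compound 1 to compound 3 (1.25 log units; beyond the scatter) were large, whereas the further step a 1.5-fold lower number from compound 2 to compound 3 (0.17 log units; within the scatter) stayed within the scatter. The gain thus appears to level off once the chain is long, with compound 2 and compound 3 indistinguishable. Whether the added butyl carries the number further down or turns it back cannot be read from these three compounds, so the expected step is a 1.3-fold lower number from compound 3 to compound 4 (0.10 log units; within the scatter), close to no change. Compound 4 is estimated at 15 nM in this assay, with a range from 5 nM to 60 nM.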

Compound 4, half-maximal inhibitory concentration: 13 nM
Beside the measured number, compound 4's estimate is 1.2-fold (0.06 log units) above it; measured number inside the range.
By their numbers in this assay, from the lowest: compounds 4, 3 and 2 (each within the scatter of the next, the first and the last beyond it); then compound 1.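

In this assay, butyl in place of hydrogen on a saturated chain carbon, eight bonds along the chain from an oxygen on an aromatic ring, gives a step that stays within the scatter (a 1.5-fold lower number from compound 3 to compound 4 (0.16 log units; within the scatter)), yet pentyl in place of hydrogen seven bonds along the chain clears it, if only modestly (a 2.2-fold lower number from compound 2 to compound 4 (0.33 log units; beyond the scatter)). Among these compounds, the plateau suggested by the earlier compounds is therefore not quite flat: over the longer span the number still falls, and the whole lengthening amounts to a large step (a 26-fold lower number from compound 1 to compound 4 (1.42 log units; beyond the scatter)). Nothing measured here gives a reason for this shape.

Going by these compounds, what a chain longer than that of compound 4 does to the number stays open. So does the effect of an amine or a carboxylic acid carried on the chain.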